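Swapping the 5-carbamoylpyridin-2-yl of compound 3 for chloro

The compounds below may be only part of what the source reports. "The series", "measured", "known", "first", "only" and "open" are said of these compounds alone.

Three measured compounds share one core and differ only in the group on the five-membered ring: compound 1 `N#Cc1ccc(-c2cnc(C(=O)CCCCCCc3ccccc3)o2)cc1`, compound 2 `Cc1ccc(-c2cnc(C(=O)CCCCCCc3ccccc3)o2)nc1` and compound 3 `NC(=O)c1ccc(-c2cnc(C(=O)CCCCCCc3ccccc3)o2)nc1`. In an assay (Rattus norvegicus) for inhibition of Fatty-acid amide hydrolase 1 (Homo sapiens) (on this read-out higher numbers stand for weaker inhibition and lower numbers for stronger inhibition), compound 1 gives 40 nM, compound 2 gives 2.8 nM and compound 3 gives 1.2 nM. The steps between them are a 14-fold lower number from compound 1 to compound 2 (1.15 log units; beyond the scatter), a 33-fold lower number from compound 1 to compound 3 (1.52 log units; beyond the scatter) and a 2.3-fold lower number from compound 2 to compound 3 (0.37 log units; beyond the scatter). Compound 3 thus stands lowest of the three, with compound 2 nearest and compound 1 furthest.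

Compound 4 `O=C(CCCCCCc1ccccc1)c1ncc(Cl)o1` removes that group entirely: chloro in place of 5-carbamoylpyridin-2-yl on an aromatic carbon. Within the data shown here, none of the measured steps bears directly on this change; all three only alter the group itself, yet even those alterations gave large moves, as in a 33-fold lower number from compound 1 to compound 3 (1.52 log units; beyond the scatter), which shows how much of the number rests on this group. Taking the whole group away is therefore expected to give a large step upward in this assay. Compound 4 is expected at 400 nM, within roughly 40 nM to 4000 nM. The expected step is a 330-fold higher number from compound 3 to compound 4 (2.52 log units; beyond the scatter).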

Compound 4, inhibition constant: 5 nM
Compound 4: middle estimate off by 80-fold (1.90 log units), on the high side; the measured number lies below the stated range.
By their numbers in this assay, from the lowest: compound 3; then compounds 2 and 4 (each within the scatter of the next); then compound 1.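

In this assay, the group on the aromatic carbon next to the ring oxygen turns out not to need an aromatic ring for a low number: a lone chloro stays close to the pyridinyl compounds (a 4.2-fold higher number from compound 3 to compound 4 (0.62 log units; beyond the scatter); a 1.8-fold higher number from compound 2 to compound 4 (0.25 log units; within the scatter)) and even improves on the phenyl one (an 8.0-fold lower number from compound 1 to compound 4 (0.90 log units; beyond the scatter)). Among these compounds, the large moves among the earlier compounds therefore reflect a penalty specific to 4-cyanophenyl rather than a general need for a big group here, while 5-carbamoylpyridin-2-yl, with its 9 heavy atoms, gains only a modest step over a single chlorine atom. Nothing at hand explains why chloro does so well.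

The compounds shown leave open whether chloro itself matters or whether bromo, a methyl or a bare hydrogen on this carbon would read the same. Also open, on these data alone, is how an unsubstituted phenyl or a carboxylic acid on the pyridine ring would fall relative to compound 4.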